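From compound 3 to compound 4: a larger chain end

A few compounds are considered here, and "the series" means these few. Any claim that something is new, unique, unknown or untested is made for them only; others in the source may bear on it.

Compound 1 `COc1ccc(S(=O)(=O)N(CC(N)=O)c2ccc(N(CC(N)=O)S(=O)(=O)c3ccc(SCCCCCN=C=S)cc3)c3ccccc23)cc1` gives the limit > 10000 nM
Compound 2 `COc1ccc(S(=O)(=O)N(CC(N)=O)c2ccc(N(CC(N)=O)S(=O)(=O)c3ccc(SCCOCCN=C=S)cc3)c3ccccc23)cc1` gives the limit > 10000 nM
Compound 3 `COc1ccc(S(=O)(=O)N(CC(N)=O)c2ccc(N(CC(N)=O)S(=O)(=O)c3ccc(S(=O)(=O)CCCN=C=S)cc3)c3ccccc23)cc1` gives the limit > 10000 nM

All three values above come from an ADME assay on cells (Peritoneal macrophage, Mus musculus) for cytotoxicity, read by CCK-8 assay, with a stated time of 24 h (on this read-out lower numbers stand for higher toxicity in this test and higher numbers for lower toxicity in this test), and none of them is an exact number. Compound 3 therefore has only a limit to its name, and it shares this position with the other two: the limit of > 10000 nM in this assay, at which 3 of the 3 values shown sit.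

Compound 4 `COc1ccc(S(=O)(=O)N(CC(N)=O)c2ccc(N(CC(N)=O)S(=O)(=O)c3ccc(S(=O)(=O)CCOCCOCCOCCN=C=S)cc3)c3ccccc23)cc1` has not yet been measured. It differs from compound 3 in one place: a group of 12 heavy atoms (7 carbon, 1 nitrogen, 3 oxygen, 1 sulfur; no ring) in place of a group of 4 heavy atoms (2 carbon, 1 nitrogen, 1 sulfur; no ring), on a saturated chain carbon, two bonds along the chain from a sulfonyl sulfur.

Going by the values given here, three measured steps bear on this change, as each alters the same side of the molecule: a step that the two limits leave unreadable from compound 1 to compound 2, a step that the two limits leave unreadable from compound 1 to compound 3 and a step that the two limits leave unreadable from compound 2 to compound 3. None of them has a readable size, so they offer no measured effect of a chain change to carry forward. They do show that these three different chains all end at the same limit. On that basis, no shift beyond the usual scatter is expected in this assay in either direction, and compound 4 is expected to reach the limit as well. The expected outcome is a step that the limit leaves unreadable from compound 3 to compound 4 for this change. For compound 4 the estimated value is 15000 nM with an expected range from 8000 nM to 40000 nM.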

Compound 4, half-maximal cytotoxic concentration: > 10000 nM
Compound 4 gave a limit, no number (the forecaster's own chance of this, stated with the estimate: 85%); the middle value is on the limit's open side.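

In this assay, going by these compounds alone, compound 4 gives a limit and no number, as compound 3 does, so no step from compound 3 to compound 4 can be read. All four compounds stand in the same place: the limit of > 10000 nM in this assay, at which 4 of the 4 values shown sit. What these compounds leave open is whether their four chains differ from one another at all in this test.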